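Swapping a Phenylsulfonyl for a Diisobutylsulfamoyl Group

A few compounds are considered here, and "the series" means these few. Any claim that something is new, unique, unknown or untested is made for them only; others in the source may bear on it.

For the measured compounds named here, compound 1 `CC1(C)Oc2ccc(S(=O)(=O)c3ccccc3)cc2[C@@H](/N=C(\NC#N)Nc2ccc(Cl)cc2)[C@@H]1O` has the lower of the two numbers so far in a functional assay (aorta) with Rattus norvegicus as the target (on this read-out lower numbers stand for stronger inhibition and higher numbers for weaker inhibition), where compound 1 gives 500 nM. Compound 2 `CC1(C)Oc2ccc(S(=O)(=O)N3CCOCC3)cc2[C@@H](/N=C(\NC#N)Nc2ccc(Cl)cc2)[C@@H]1O`, carrying morpholin-4-yl in place of phenyl on the sulfonyl sulfur, gives 3100 nM, a step of a 6.2-fold higher number from compound 1 to compound 2 (0.79 log units; beyond the scatter). Compound 3 `CC(C)CN(CC(C)C)S(=O)(=O)c1ccc2c(c1)[C@@H](/N=C(\NC#N)Nc1ccc(Cl)cc1)[C@H](O)C(C)(C)O2` makes a related change: diisobutylamino in place of phenyl on a sulfonyl sulfur. Going by the values given here, since the only comparable step weakened inhibition, a weaker result is expected, estimated as a 3.0-fold higher number from compound 1 to compound 3 (0.48 log units; beyond the scatter). Compound 3 is therefore expected to give about 1500 nM, within a range of 400 nM to 6000 nM.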

Compound 3, half-maximal inhibitory concentration: 9400 nM
The estimate for compound 3 lay 6.3-fold (0.80 log units) below the measured number, outside the stated range (above it).
By their numbers in this assay, from the lowest: compound 1; then compound 2; then compound 3.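

In this assay, replacing phenyl on the sulfonyl sulfur with diisobutylamino costs much more inhibition (a 19-fold higher number from compound 1 to compound 3 (1.27 log units; beyond the scatter)) than the morpholin-4-yl swap did, and compound 3 also falls short of compound 2 (a 3.0-fold higher number from compound 2 to compound 3 (0.48 log units; beyond the scatter)). The loss is therefore not peculiar to morpholin-4-yl: both amino groups shown fall behind phenyl, and the open-chain one falls furthest. No measurement here explains this order. As far as these compounds go, whether a small dimethylamino group would stay closer to compound 1 remains open. So does whether a piperidin-1-yl ring would match morpholin-4-yl.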